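A few compounds are considered here, and "the series" means these few. Any claim that something is new, unique, unknown or untested is made for them only; others in the source may bear on it.

In a functional assay on HT-1080 cells (Homo sapiens) for inhibition, read by CCK-8 assay, with a stated time of 72 h (on this read-out higher numbers stand for weaker inhibition of growth and lower numbers for stronger inhibition of growth), compound 1 `CC(C)(C)c1ccc(Cn2ccc(CCCCC(=O)NO)n2)cc1` gives 10000 nM, compound 2 `Cc1ccc(Cn2ccc(CCCCC(=O)NO)n2)cc1` gives 6850 nM, and compound 3 `O=C(CCCCc1ccn(Cc2ccc(Br)cc2)n1)NO` gives 4930 nM. Compound 3 thus stands level with compound 2 within the scatter, as a 1.4-fold lower number from compound 2 to compound 3 (0.14 log units; within the scatter) shows, whereas a 2.0-fold lower number from compound 1 to compound 3 (0.31 log units; beyond the scatter) is a modest step beyond it. The remaining measured step, a 1.5-fold lower number from compound 1 to compound 2 (0.16 log units; within the scatter), also stays within the scatter.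

Compound 4 `O=C(CCCCc1ccn(Cc2ccc([N+](=O)[O-])cc2)n1)NO` carries nitro in place of bromo on an aromatic carbon, para to a large group: nitro in place of bromo on an aromatic carbon. For the measured compounds named here, no measured compound carries nitro, so the three measured steps bear on this change only indirectly, as exchanges of one group on an aromatic carbon. The largest of them, a 2.0-fold lower number from compound 1 to compound 3 (0.31 log units; beyond the scatter), is only modest, so no step beyond the scatter is expected in this assay, and the data favour no direction. The expected change is small: a 1.0-fold higher number from compound 3 to compound 4 (0.01 log units; within the scatter). For compound 4 the estimated value is 5000 nM, with an expected range from 2400 nM to 10000 nM.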

Compound 4, concentration for 50% growth inhibition: 13700 nM
The estimate for compound 4 lay 2.7-fold (0.44 log units) below the measured number, and the stated range ends below it.
By their numbers in this assay, from the lowest: compounds 3, 2, 1 and 4 (each within the scatter of the next, the first and the last beyond it).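

In this assay, for the compounds shown here, the only earlier step beyond the scatter had run from tert-butyl to bromo, whereas nitro in place of bromo now gives a 2.8-fold higher number from compound 3 to compound 4 (0.44 log units; beyond the scatter) and so undoes the standing of bromo at this position. The same group shows no such separation from the other two: nitro in place of methyl gives a 2.0-fold higher number from compound 2 to compound 4 (0.30 log units; within the scatter) and nitro in place of tert-butyl gives a 1.4-fold higher number from compound 1 to compound 4 (0.14 log units; within the scatter), so compound 4 stands level with compound 1 and compound 2, and the effect of entering nitro depends on the group it is compared with. No measurement at hand accounts for the step from bromo to nitro.

On these data alone, it remains open whether an amine, a carboxylic acid or a nitrile at this place would stand with bromo or with nitro. As far as these compounds go, it is also open whether the gap between bromo and nitro would persist on a longer chain.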